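The source may hold more compounds than are shown below. What is called first, only, known or untested is meant among the compounds shown, and "the series" means these compounds.

Of the compounds shown here, three have been measured; all share one core and differ only in the group attached to a carbonyl carbon that sits on an aromatic carbon. In an assay on cells for agonist activity at vitamin D3 receptor (Homo sapiens), with a stated time of 96 h (a lower number here means that less compound is needed, a higher number that more compound is needed for the effect), compound 1 `CCn1c(C(=O)NCCCN(C)C)ccc1C(CC)(CC)c1ccc(OCCC(O)(CC)CC)c(C)c1` gives 5 nM. Compound 3 `C#CC(C)OC(=O)c1ccc(C(CC)(CC)c2ccc(OCCC(O)(CC)CC)c(C)c2)n1CC` gives 2650 nM. For compound 2 `CCn1c(C(=O)N(CCC#N)CCC#N)ccc1C(CC)(CC)c1ccc(OCCC(O)(CC)CC)c(C)c1` the assay reports only a limit, > 10000 nM, not a number.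

Among the two real numbers, compound 3 has the higher one: the step from compound 1 to compound 3 is a 530-fold higher number from compound 1 to compound 3 (2.72 log units; beyond the scatter). Against compound 2, whose value is a limit, the picture is an at least 3.7-fold lower number from compound 2 to compound 3 (0.57 log units; beyond the scatter), so compound 3 sits between the two in this assay.

Compound 4 `CCOC(=O)C(CC(=O)OC)NC(=O)c1ccc(C(CC)(CC)c2ccc(OCCC(O)(CC)CC)c(C)c2)n1CC` is the next variation at the same carbonyl carbon: a group of 12 heavy atoms (7 carbon, 1 nitrogen, 4 oxygen; no ring) in place of a group of 5 heavy atoms (4 carbon, 1 oxygen; no ring), on a carbonyl carbon. The group that enters carries a hydrogen-bond donor, as the group in compound 1 does, but no amine.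

All three measured steps change this same position, and all were large or at least modest: an at least 2000-fold higher number from compound 1 to compound 2 (3.30 log units; beyond the scatter), a 530-fold higher number from compound 1 to compound 3 (2.72 log units; beyond the scatter) and an at least 3.7-fold lower number from compound 2 to compound 3 (0.57 log units; beyond the scatter). Going by the values given here, the group on this carbonyl therefore matters greatly, yet none of the measured groups closely resembles the one in compound 4, so the direction is uncertain. A moderate move toward lower numbers is expected, with a wide range, giving a 2.7-fold lower number from compound 3 to compound 4 (0.42 log units; beyond the scatter) as the estimated step. For compound 4 the expected value in this assay is 1000 nM, estimated to lie between 150 nM and 8000 nM.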

Compound 4, half-maximal effective concentration: 21 nM
For compound 4 the middle estimate is 48-fold (1.68 log units) above the measured one; the measured number lies below the stated range.
By their numbers in this assay, from the lowest: compound 1; then compound 4; then compound 3. At a limit, above all of these: compound 2.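

In this assay, replacing (1-methylprop-2-yn-1-yl)oxy on the carbonyl carbon with a larger group that has a hydrogen-bond donor gives a 130-fold lower number from compound 3 to compound 4 (2.10 log units; beyond the scatter), so a low number at this position does not depend on an amine. The amine-free group of compound 4 still gives a modest change relative to the amine-bearing group, a 4.2-fold higher number from compound 1 to compound 4 (0.62 log units; beyond the scatter). Group size alone does not set the result, as the group of 9 heavy atoms in compound 2, smaller than the entering group, gives an at least 470-fold lower number from compound 2 to compound 4 (2.67 log units; beyond the scatter), where the value for compound 2 is only a limit: the limit of > 10000 nM in this assay, at which 1 of the 4 values shown sits.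

On these data alone, it remains open which part of the entering group matters, the amide hydrogen or the ester-bearing chains. How a carboxylic acid in place of either ester, or a plain ethyl chain on the same nitrogen, would behave in this assay is also unknown.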